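This account rests on a few compounds, and the source may have more. Where it says the series, first, only, none or still open, it means among the compounds named here.

Compound 3 `O=C(CSc1ccc(Br)cc1)N1N=C(c2cc3ccccc3oc2=O)C[C@@H]1c1ccc(C(F)(F)F)cc1` is a hydrazone-type compound whose core carries a coumarin ring, a trifluoromethylphenyl group and a (4-bromophenyl)sulfanyl arm on the amide side chain. In a functional assay on MGC-803 cells (Homo sapiens) for cytotoxicity, read by MTT assay, with a stated time of 48 h (on this read-out higher numbers stand for weaker inhibition and lower numbers for stronger inhibition), compound 3 gives 10800 nM, the second highest of the three numbers recorded. Going by the values given here, compound 2 `CC1=NN(C(=O)CSc2ccccc2)[C@@H](c2cc(Br)cc(Br)c2O)C1` gives 12700 nM in this assay, and that value and the one for compound 3 lie within the scatter of each other. Among the compounds with values here, compound 1 `O=C(CSc1ncccn1)N1N=C(c2cc3ccccc3oc2=O)C[C@@H]1c1ccc(C(F)(F)F)cc1` gives 2890 nM, and the change to compound 3 is a 3.7-fold higher number from compound 1 to compound 3 (0.57 log units; beyond the scatter), the only measured step, and it concerns the group on the sulfur.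

Compound 4 `O=C(CSc1ccc([N+](=O)[O-])cc1)N1N=C(c2cc3ccccc3oc2=O)C[C@@H]1c1ccc(C(F)(F)F)cc1` differs from compound 3 by nitro in place of bromo on an aromatic carbon. Within the data shown here, no measured step exchanges one group for another on this phenyl ring, so the only guide is that the step from compound 1 to compound 3 a 3.7-fold higher number from compound 1 to compound 3 (0.57 log units; beyond the scatter) was modest when the whole aryl on the sulfur was changed. The expected step is therefore small, a 1.4-fold lower number from compound 3 to compound 4 (0.13 log units; within the scatter), with no firm direction. Compound 4 is estimated at 8000 nM, within a range from 3500 nM to 25000 nM.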

Compound 4, half-maximal inhibitory concentration: 10200 nM
The estimate for compound 4 lay 1.3-fold (0.11 log units) below the measured number; measured number inside the range.
By their numbers in this assay, from the lowest: compound 1; then compounds 4, 3 and 2 (each within the scatter of the next).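

In this assay, putting nitro in place of bromo on the phenyl ring, para to a large group, gives a step that stays within the scatter (a 1.1-fold lower number from compound 3 to compound 4 (0.02 log units; within the scatter)), so compound 3 and compound 4 cannot be told apart even though nitro brings more heavy atoms and two hydrogen-bond acceptors. The gap to the pyrimidin-2-yl compound appears again with this second phenyl group (a 3.5-fold higher number from compound 1 to compound 4 (0.55 log units; beyond the scatter)), so among these three compounds it does not depend on bromo alone. No measurement shown here offers a reason for either result.

Still open, on these data alone, is whether an amine or a carboxylic acid in that same place on the phenyl ring would match bromo and nitro. Also open, as far as these compounds go, is whether a pyridin-2-yl group on the sulfur would match compound 1 or compound 3.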